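Moving the Nitro Group in a Nucleoside Transporter Inhibitor

The source may hold more compounds than are shown below. What is called first, only, known or untested is meant among the compounds shown, and "the series" means these compounds.

Measured so far:
Compound 1 `OC[C@H]1O[C@@H](n2cnc3c(SCc4ccccc4Br)ncnc32)[C@H](O)[C@@H]1O`: 151 nM
Compound 2 `O=[N+]([O-])c1ccccc1CSc1ncnc2c1ncn2[C@@H]1O[C@H](CO)[C@@H](O)[C@H]1O`: 115 nM

Going by the values given here, in an assay on isolated protein for inhibition of Equilibrative nucleoside transporter 1 (Homo sapiens) (a lower number here means a stronger inhibitor, a higher number a weaker inhibitor), compound 2 gives 115 nM, and compound 1 gives 151 nM; the two sit within the scatter of each other, the only measured step being a 1.3-fold lower number from compound 1 to compound 2 (0.12 log units; within the scatter). Compound 3 `O=[N+]([O-])c1cccc(CSc2ncnc3c2ncn3[C@@H]2O[C@H](CO)[C@@H](O)[C@H]2O)c1` differs from compound 2 by 3-nitrophenyl in place of 2-nitrophenyl on a saturated chain carbon bound to a sulfur. Among the compounds with values here, no measured step shifts a group from one ring position to another; the step from compound 1 to compound 2 exchanged one substituent for another at the same place and stayed within the scatter, so it bears only loosely on the present change. With nothing pointing either way, the expectation for compound 3 is a number close to that of compound 2, with a 1.1-fold higher number from compound 2 to compound 3 (0.05 log units; within the scatter) taken as no step beyond the scatter. Compound 3 is therefore estimated at 130 nM, within a range from 45 nM to 400 nM.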

Compound 3, inhibition constant: 1.78 nM
The estimate for compound 3 lay 73-fold (1.86 log units) above the measured number; measured number outside the range, below it.
By their numbers in this assay, from the lowest: compound 3; then compounds 2 and 1 (each within the scatter of the next).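

In this assay, the step of 3-nitrophenyl in place of 2-nitrophenyl on a saturated chain carbon bound to a sulfur gives a 65-fold lower number from compound 2 to compound 3 (1.81 log units; beyond the scatter) with the same atoms joined differently, so where the nitro group sits matters greatly at this place. The change from 2-bromophenyl to 3-nitrophenyl gives an 85-fold lower number from compound 1 to compound 3 (1.93 log units; beyond the scatter) as well, whereas nitro in place of bromo on the same aromatic carbon had stayed within the scatter, and only compound 3 stands apart among the three. No supporting evidence accompanies these numbers to account for the step. From the compounds shown here alone, whether bromo in place of the nitro group of compound 3 would keep its number remains open. So does what an amine, a carboxylic acid or a nitrile would do there.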